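Amide-end swap in a sulfonamide series and solubility

The source may report more compounds than this note shows. Statements on the series, on what has been measured and on what is new or still open speak of the compounds shown alone.

Compound 1 `CN(C)CC(=O)N1CCC(NS(=O)(=O)c2cc(S(=O)(=O)c3ccccc3)ccc2C(F)(F)F)CC1` is a sulfonamide bearing a (dimethylamino)methyl carbonyl group on its ring nitrogen. In a physicochemical assay for solubility (a higher number here means a more soluble compound, a lower number a less soluble compound), compound 1 gives 100000 nM, level with compound 2 `CC(C)C(=O)N1CCC[C@H]1C(=O)N1CCC(NS(=O)(=O)c2cc(S(=O)(=O)c3ccccc3)ccc2C(F)(F)F)CC1`, which gives 100000 nM, and compound 3 `CCNC(=O)N1CCC[C@H]1C(=O)N1CCC(NS(=O)(=O)c2cc(S(=O)(=O)c3ccccc3)ccc2C(F)(F)F)CC1`, which gives 100000 nM. The steps of no change at the digits printed from compound 1 to compound 2 (within the scatter) and no change at the digits printed from compound 1 to compound 3 (within the scatter) show no change at the digits measured, as does no change at the digits printed from compound 2 to compound 3 (within the scatter). Compound 4 `CN1CCC[C@H]1C(=O)N1CCC(NS(=O)(=O)c2cc(S(=O)(=O)c3ccccc3)ccc2C(F)(F)F)CC1` differs from compound 1 by 1-methylpyrrolidin-2-yl in place of (dimethylamino)methyl on a carbonyl carbon. The three measured steps, all replacements on the same carbonyl carbon, were flat, so no step beyond the scatter is expected here either, with no change at the digits printed from compound 1 to compound 4 (within the scatter) expected. Compound 4 is therefore estimated at 100000 nM, with a range of 50000 nM to 100000 nM.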

Compound 4, solubility: 100000 nM
Beside the measured number, compound 4's estimate shows no gap at the digits printed, within the range that was stated.
By their numbers in this assay, from the lowest: compounds 1, 2, 3 and 4 (each within the scatter of the next).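

In this assay, replacing the open (dimethylamino)methyl with the ring-bearing 1-methylpyrrolidin-2-yl on the carbonyl carbon gives no change at the digits printed from compound 1 to compound 4 (within the scatter). On the amine nitrogen in the ring, methyl in place of ethylcarbamoyl gives no change at the digits printed from compound 3 to compound 4 (within the scatter), and methyl in place of isopropylcarbonyl gives no change at the digits printed from compound 2 to compound 4 (within the scatter), so the flat picture now extends to a simple methyl on that nitrogen. Nothing available accounts for this result.

The compounds shown leave open whether a carboxylic acid, a longer alkyl chain or a phenyl ring on this carbonyl carbon would read differently in this assay.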